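Nitroimidazo-oxazine ethers: Vero cytotoxicity across a cyano-to-fluoro swap

The compounds below may be only part of what the source reports. "The series", "measured", "known", "first", "only" and "open" are said of these compounds alone.

Measured so far:
- compound 1, `N#Cc1ccc(-c2cccc(CO[C@@H]3COc4nc([N+](=O)[O-])cn4C3)c2)cc1`: > 128000 nM
- compound 2, `O=[N+]([O-])c1cn2c(n1)OC[C@@H](OCc1cccc(-c3ccc(F)cc3)c1)C2`: > 128000 nM
- compound 3, `N#Cc1ccc(-c2nc(CO[C@@H]3COc4nc([N+](=O)[O-])cn4C3)cs2)cc1`: > 128000 nM

All values come from an ADME assay on Vero cells (Chlorocebus sabaeus) for cytotoxicity, with a stated time of 72 h; a lower number here means a stronger inhibitor, a higher number a weaker inhibitor. For compound 1 the value > 128000 nM is a limit of the assay, not a number. For compound 2 the value > 128000 nM is likewise a limit. For compound 3 the value > 128000 nM is a limit as well.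

The change from compound 1 to compound 2 is fluoro in place of cyano on an aromatic carbon. The matching step, a step that the two limits leave unreadable from compound 1 to compound 2, cannot be read, because of the limit of > 128000 nM in this assay, at which 3 of the 3 values shown sit.

The difference between the core of compound 1 and the core of compound 3 is not broken down here.

Compound 4, `O=[N+]([O-])c1cn2c(n1)OC[C@@H](OCc1csc(-c3ccc(F)cc3)n1)C2`, is not yet measured in this assay. It differs from compound 3 by fluoro in place of cyano on an aromatic carbon, the same change as that from compound 1 to compound 2, at a place described in the same words. Because (the limit of > 128000 nM in this assay, at which 3 of the 3 values shown sit), there is no measured size for this change to transfer. The expectation for compound 4 is therefore that it, too, will sit at the limit, and the step that the limit leaves unreadable from compound 3 to compound 4 is expected to be unreadable in the same way. Compound 4 is estimated at 200000 nM in this assay, with a range from 100000 nM to 600000 nM.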

Compound 4, half-maximal inhibitory concentration: > 128000 nM
Compound 4: no number, only a limit (the forecaster's own chance of this, stated with the estimate: 90%); the middle value lies beyond the limit too.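

In this assay, the change from 4-cyanophenyl to 4-fluorophenyl gives no readable step between compound 3 and compound 4, because both values are limits of the assay and not numbers: the limit of > 128000 nM in this assay, at which 4 of the 4 values shown sit.

The compounds shown leave open where compound 1, compound 2, compound 3 and compound 4 truly lie in this assay, and whether this change has any effect there on either core.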